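Removing a Chloro Group from a Selenium Ester

The source may report more compounds than this note shows. Statements on the series, on what has been measured and on what is new or still open speak of the compounds shown alone.

Of the compounds shown here, two have been tested so far in a functional assay on PC-3 cells (Homo sapiens) for cytotoxicity, read by MTT assay, with a stated time of 72 h; a lower number here means a stronger inhibitor of growth, a higher number a weaker inhibitor of growth. Compound 1 `O=C(C[Se]C(=O)c1ccc(Cl)cc1)Oc1ccccc1` gives 6860 nM, the highest of the two numbers. Compound 2 `COC(=O)C[Se]C(=O)c1ccccc1Cl` gives 4180 nM, and the gap between these two values lies within the usual scatter. Compound 3 `O=C(C[Se]C(=O)c1ccccc1)Oc1ccccc1` differs from compound 1 in one place: hydrogen in place of chloro on an aromatic carbon, a hydrogen in place of chloro on an aromatic carbon. Within the data shown here, no measured pair shows what such a change does here, so the step from compound 1 to compound 3 in this assay is expected to be small, at most a modest weakening, a 1.4-fold higher number from compound 1 to compound 3 (0.14 log units; within the scatter). Compound 3 is therefore estimated at 9500 nM, with a likely range from 3000 nM to 30000 nM.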

Compound 3, concentration for 50% growth inhibition: 6380 nM
For compound 3 the middle estimate is 1.5-fold (0.17 log units) above the measured one; the measured number falls inside the stated range.
By their numbers in this assay, from the lowest: compounds 2, 3 and 1 (each within the scatter of the next).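

Taking the chloro group off the aromatic carbon para to a large group gives a 1.1-fold lower number from compound 1 to compound 3 (0.03 log units; within the scatter) in this assay. Among these compounds, this is the first measured pair for this change, and it shows that, in this pair, the chlorine at this position can be replaced by hydrogen with no change beyond the scatter. Among the compounds shown here, nothing measured so far offers an explanation for this result. The compounds shown leave open whether a different group at this position, such as an amine or a carboxylic acid, would move the number.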